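This account rests on a few compounds, and the source may have more. Where it says the series, first, only, none or still open, it means among the compounds named here.

Compound 1 `CC1CCN(C2CCN(S(=O)(=O)c3cccc(C(F)(F)F)c3)CC2)CC1` was tested in an ADME assay on HCT-116 cells (Homo sapiens) for cytotoxicity, read by CellTiter-Glo, with a stated time of 72 h; on this read-out lower numbers stand for stronger inhibition and higher numbers for weaker inhibition. In this assay compound 1 gives only the limit > 5000 nM, so no number is known for it. Its neighbours sit the same way. Compound 2 `CC1CCN(C2CCN(S(=O)(=O)c3ccc(Cl)c(C(F)(F)F)c3)CC2)CC1` also gives in this assay only the limit > 5000 nM. Compound 3 `CC1CCN(C2CCN(S(=O)(=O)c3ccc(OC(F)(F)F)cc3)CC2)CC1` likewise gives in this assay only the limit > 5000 nM. For the measured compounds named here, the single one-place step among the measured compounds, a step that the two limits leave unreadable from compound 1 to compound 2, is therefore unreadable, and the reason is plain: the limit of > 5000 nM in this assay, at which 3 of the 3 values shown sit. Compound 4 `Cc1cc(C)cc(-c2cccc(S(=O)(=O)N3CCC(N4CCC(C)CC4)CC3)c2)c1` differs from compound 1 by 3,5-dimethylphenyl in place of trifluoromethyl on an aromatic carbon. Going by the values given here, no measured step bears readably on this change, and every value in this assay is a limit, so nothing in the data points to a step in either direction beyond the scatter. The expectation for compound 4 is accordingly an estimated step that the limit leaves unreadable from compound 1 to compound 4, most likely again ending at the limit. For compound 4 in this assay the estimate is 6000 nM, with a range from 2000 nM to 20000 nM.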

Compound 4, half-maximal inhibitory concentration: > 5000 nM
Compound 4 was reported as a limit (the forecaster's own chance of this, stated with the estimate: 65%); the middle value is on the limit's open side.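

In this assay compound 4 gives only the limit > 5000 nM. No step between compound 1 and compound 4 can be read, and the reason is this: the limit of > 5000 nM in this assay, at which 4 of the 4 values shown sit.

The compounds shown leave open how far any of them lies from that limit, and whether any change to the shared core would give a measurable number in this assay.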